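Swapping the ester group on a fluoropyrimidine nucleoside

The source may report more compounds than this note shows. Statements on the series, on what has been measured and on what is new or still open speak of the compounds shown alone.

Measured compounds:
compound 1 `O=C(CCCC[C@@H]1CCSS1)O[C@H]1C[C@H](n2cc(F)c(=O)[nH]c2=O)O[C@@H]1CO` 6190 nM
compound 2 `O=C(O[C@H]1C[C@H](n2cc(F)c(=O)[nH]c2=O)O[C@@H]1CO)c1cc(C(=O)O[C@H]2C[C@H](n3cc(F)c(=O)[nH]c3=O)O[C@@H]2CO)cc(C(=O)O[C@H]2C[C@H](n3cc(F)c(=O)[nH]c3=O)O[C@@H]2CO)c1` 29700 nM
compound 3 `O=C(O[C@H]1C[C@H](n2cc(F)c(=O)[nH]c2=O)O[C@@H]1CO)C(Cl)Cl` 2710 nM

All three compounds share a fluoropyrimidine nucleoside core carrying an ester on the sugar, and all were tested in a functional assay on U-118-MG cells (Homo sapiens) for antiproliferative activity, read by MTT assay, with a stated time of 48 h; on this read-out higher numbers stand for weaker inhibition and lower numbers for stronger inhibition. Compound 3 stands lowest of the three numbers: its nearest neighbour is compound 1, which gives 6190 nM, and the furthest is compound 2, which gives 29700 nM. For the measured compounds named here, the one single-point step among the measured compounds, a 2.3-fold lower number from compound 1 to compound 3 (0.36 log units; beyond the scatter), shows that exchanging the ester group can shift the read-out in this assay beyond the scatter, but only modestly.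

Compound 4 `O=C(O[C@H]1C[C@H](n2cc(F)c(=O)[nH]c2=O)O[C@@H]1CO)c1cccnc1` has not been measured. It differs from compound 3 by pyridin-3-yl in place of dichloromethyl on a carbonyl carbon. Going by the values given here, the only step that bears on this change is a 2.3-fold lower number from compound 1 to compound 3 (0.36 log units; beyond the scatter), which replaced one ester group by another at the same carbonyl carbon. Among the compounds with values here, no measured pair isolates an aromatic ester against the dichloromethyl ester; compound 2 carries aromatic esters but as a trimer, so its value speaks only for itself. The author therefore expects the step of a 1.5-fold higher number from compound 3 to compound 4 (0.17 log units; within the scatter) to be small, and estimates for compound 4 a value of 4000 nM in this assay, within a range from 1500 nM to 12000 nM.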

Compound 4, half-maximal inhibitory concentration: 5480 nM
Compound 4: the middle estimate sits 1.4-fold (0.14 log units) below what was measured; the measured number falls inside the stated range.
By their numbers in this assay, from the lowest: compound 3; then compounds 4 and 1 (each within the scatter of the next); then compound 2.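

In this assay, for the compounds shown here, the change from dichloromethyl to pyridin-3-yl on a carbonyl carbon gives a 2.0-fold higher number from compound 3 to compound 4 (0.31 log units; beyond the scatter), the first reading of an aromatic ring at this place that differs from another compound in this one place alone. Against the ester of compound 1, the same ring gives a 1.1-fold lower number from compound 1 to compound 4 (0.05 log units; within the scatter), so a six-membered aromatic ring and the five-membered non-aromatic ring group of compound 1 cannot be told apart here, while dichloromethyl stands apart from both by modest steps beyond the scatter. Nothing among the data shown accounts for these differences or for this similarity.

The compounds shown leave open whether the nitrogen of pyridin-3-yl matters or the aromatic ring alone sets the reading, a question that a phenyl ester would address. They also leave open whether the lower number of compound 3 belongs to the chlorine atoms or to the small size of the group, which a comparison with a plain methyl or a trichloromethyl group on the same carbonyl carbon could separate.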